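Working notes: carbonyl substituent change from compound 2 to compound 4

This account rests on a few compounds, and the source may have more. Where it says the series, first, only, none or still open, it means among the compounds named here.

All numbers come from a functional assay on PC-3 cells (Homo sapiens) for cytotoxicity, read by MTT assay, with a stated time of 48 h; on this read-out higher numbers stand for weaker inhibition and lower numbers for stronger inhibition.

Measured so far:
compound 1 `COc1cc(-c2nnc3n2NC(c2ccco2)C(C(=O)c2ccccc2C)S3)cc(OC)c1OC`: 88400 nM
compound 2 `COc1cc(-c2nnc3n2NC(c2ccco2)C(C(=O)c2ccc(Br)cc2)S3)cc(OC)c1OC`: 36400 nM
compound 3 `COc1cc(-c2nnc3n2NC(c2cccs2)C(C(=O)c2ccc(C)cc2)S3)cc(OC)c1OC`: 5090 nM

Compound 2 holds the second highest of the three numbers. Among the compounds with values here, its nearest neighbour is compound 1, and the only one-place step in the set, a 2.4-fold lower number from compound 1 to compound 2 (0.39 log units; beyond the scatter), is the swap of 2-methylphenyl for 4-bromophenyl on the carbonyl carbon. Within the data shown here, compound 3 differs from compound 2 in two places and shows a clearly lower number; no single step covers that pair, so only the two values themselves speak.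

Compound 4 `COc1cc(-c2nnc3n2NC(c2ccco2)C(C(=O)C2CC2)S3)cc(OC)c1OC` is not yet measured. Relative to compound 2 the change is cyclopropyl in place of 4-bromophenyl on a carbonyl carbon. Among the measured compounds shown here, none of the measured steps replaces the aromatic ring on the carbonyl carbon with a non-aromatic ring; the step from compound 1 to compound 2 only shows that altering the aryl group there moves this assay by a modest amount. The expectation is therefore a step of at most modest size, with the direction uncertain and a slight lean towards a higher number.

Compound 4 is expected at 50000 nM, with a range from 15000 nM to 160000 nM. This estimate means an expected step of a 1.4-fold higher number from compound 2 to compound 4 (0.14 log units; within the scatter).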

Compound 4, half-maximal inhibitory concentration: 95200 nM
Estimate against measurement, compound 4: 1.9-fold (0.28 log units) below; low and high end bracket the measured number.
By their numbers in this assay, from the lowest: compound 3; then compound 2; then compounds 1 and 4 (each within the scatter of the next).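

Cyclopropyl in place of 4-bromophenyl on the carbonyl carbon gives, in this assay, a 2.6-fold higher number from compound 2 to compound 4 (0.42 log units; beyond the scatter) and is beyond the scatter, the first reading of a non-aromatic ring at this position. Cyclopropyl in place of 2-methylphenyl gives a 1.1-fold higher number from compound 1 to compound 4 (0.03 log units; within the scatter) and stays within the scatter, so the same incoming group separates from one departing aryl group but not from the other. Among compounds 1, 2 and 4, the read-out at this position therefore does not follow a simple aromatic versus non-aromatic division, and no accompanying data offer an explanation for either step.

As far as these compounds go, it remains open how an open-chain group such as n-butyl, or a phenyl ring carrying a carboxylic acid or a dimethylamino group, would read on the same carbonyl carbon. Also open is whether cyclopropyl would produce a comparable step on the core of compound 3, which gives 5090 nM in this assay and has no one-place partner among the compounds shown.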